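A few compounds are considered here, and "the series" means these few. Any claim that something is new, unique, unknown or untested is made for them only; others in the source may bear on it.

Three compounds have been measured in an assay on HEK293 cells for agonist activity at Toll-like receptor 8 (Homo sapiens), read by a luciferase reporter, with a stated time of 6 h; on this read-out higher numbers stand for an effect only at larger amounts of compound and lower numbers for an effect already at smaller amounts:

compound 1, `CCCCNc1nc(N)nc2c1CN(C)CC2`: 0.03 uM
compound 2, `CCCCNc1nc(N)nc2c1CN(Cc1ccccn1)CC2`: 0.07 uM
compound 3, `CCCCNc1nc(N)nc2c1CN(C(=O)C(C)C)CC2`: 1.6 uM

Compound 3 stands at the highest number of the three, so it needs the largest amount to show an effect: a 53-fold higher number from compound 1 to compound 3 (1.73 log units; beyond the scatter) and a 23-fold higher number from compound 2 to compound 3 (1.36 log units; beyond the scatter). Both steps put a carbonyl-bearing group on the ring nitrogen and both were large.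

Compound 4 `CCCCNc1nc(N)nc2c1CN(C(=O)c1cnccn1)CC2` keeps that carbonyl and differs from compound 3 only by pyrazin-2-yl in place of isopropyl on a carbonyl carbon. Going by the values given here, no measured step changes the group on the carbonyl carbon, so nothing bears on this change directly. The nearest guide is a 2.3-fold higher number from compound 1 to compound 2 (0.37 log units; beyond the scatter), in which a six-membered aromatic ring with a nitrogen entered on a chain carbon bound to the ring nitrogen and gave only a modest weakening. On that guide, a small step in this assay is expected, most likely a slight rise or none beyond the scatter.

Compound 4 is therefore expected to give 2.5 uM, in the range 0.7 uM to 8 uM, which means an expected step of a 1.6-fold higher number from compound 3 to compound 4 (0.19 log units; within the scatter).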

Compound 4, minimum effective concentration: 2.2 uM
For compound 4 the middle estimate is 1.1-fold (0.06 log units) above the measured one; low and high end bracket the measured number.
By their numbers in this assay, from the lowest: compound 1; then compound 2; then compounds 3 and 4 (each within the scatter of the next).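

In this assay, the group on the carbonyl carbon makes no clear difference: a 1.4-fold higher number from compound 3 to compound 4 (0.14 log units; within the scatter), so pyrazin-2-yl, with its aromatic ring and 2 hydrogen-bond acceptors, cannot be told apart from isopropyl at this place. The large gap seen earlier for an isopropylcarbonyl group on the ring nitrogen also appears with (pyrazin-2-yl)carbonyl, as shown by a 31-fold higher number from compound 2 to compound 4 (1.50 log units; beyond the scatter) and by a 73-fold higher number from compound 1 to compound 4 (1.87 log units; beyond the scatter). No measurement is available here that would explain these results.

Only isopropyl and pyrazin-2-yl are shown on the carbonyl carbon, so a longer chain or an amine there could still shift the number. Going by these compounds, it also remains open whether a group such as a carboxylic acid at this place would leave the number unchanged.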